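Methoxy for butyl on the aryl ring of compound 2

This account rests on a few compounds, and the source may have more. Where it says the series, first, only, none or still open, it means among the compounds named here.

Two measured compounds carry the shared core: compound 1 `Cc1cccc(-n2cc(COC(=O)c3cc4ccccc4[nH]3)nn2)c1C` and compound 2 `CCCCc1ccc(-n2cc(COC(=O)c3cc4ccccc4[nH]3)nn2)cc1`. In a functional assay on HeLa cells (Homo sapiens) for cytotoxicity, read by MTT assay, with a stated time of 48 h (a lower number here means a stronger inhibitor, a higher number a weaker inhibitor), compound 1 gives 30300 nM. For compound 2, this assay reports only a limit, > 200000 nM. Compound 2 thus stands at the weaker end of the two values shown, at the limit of > 200000 nM in this assay, at which 1 of the 2 values shown sits. Going by the values given here, no step between measured compounds is available to lean on. Compound 3 `COc1ccc(-n2cc(COC(=O)c3cc4ccccc4[nH]3)nn2)cc1` follows from compound 2 by methoxy in place of butyl on an aromatic carbon of a six-membered aromatic ring of carbon only, para to a large group. Among the compounds with values here, the expected step of an at least 2.0-fold lower number from compound 2 to compound 3 (0.30 log units; that floor lies within the scatter) runs downward and beyond the scatter, though it rests on no measured step. Compound 3 is therefore estimated at 100000 nM in this assay, with a range from 25000 nM to 200000 nM, and a limit rather than a number remains a real possibility.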

Compound 3, half-maximal inhibitory concentration: 16100 nM
Estimate against measurement, compound 3: 6.2-fold (0.79 log units) above, and the stated range ends above it.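

Going by these compounds alone, on an aromatic carbon of the six-membered ring, para to a large group, methoxy in place of butyl gives the first measured step at this position in this assay: an at least 12-fold lower number from compound 2 to compound 3 (1.09 log units; beyond the scatter), beyond the scatter, with its full size unknown. Compound 2 stands only as a limit of the assay, not as a number: the limit of > 200000 nM in this assay, at which 1 of the 3 values shown sits.
The change from 2,3-dimethylphenyl to 4-methoxyphenyl on the aromatic nitrogen gives a 1.9-fold lower number from compound 1 to compound 3 (0.27 log units; within the scatter), so compound 1 and compound 3 are not separated in this assay.

From the compounds shown here alone, whether the step follows the length of the chain at this position remains open; ethyl or propyl in the same place would bear on that. Also open, going by these compounds, is whether the oxygen of methoxy matters, which an ethyl, a hydroxyl or an amine at that carbon could test.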